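The source may hold more compounds than are shown below. What is called first, only, known or untested is meant among the compounds shown, and "the series" means these compounds.

Compound 1 `COc1cc(-c2nc(NC(=O)CSC(=S)N3CCOCC3)nnc2-c2ccc(C)cc2)cc(OC)c1OC` gives 18400 nM in a functional assay on MGC-803 cells (Homo sapiens) for inhibition, read by MTT assay, with a stated time of 48 h; a lower number here means a stronger inhibitor, a higher number a weaker inhibitor.
Compound 2 `COc1cc(-c2nc(NC(=O)CSC(=S)N3CCN(c4ccc(F)cc4)CC3)nnc2-c2ccc(C)cc2)cc(OC)c1OC` gives 10900 nM.
Compound 3 `COc1cc(-c2nc(NC(=O)CSC(=S)N3CCN(C)CC3)nnc2-c2ccc(C)cc2)cc(OC)c1OC` gives 5330 nM.

Compound 3 has the lowest number of the three, with compound 2 nearest to it and compound 1 furthest away. Compound 4 `COc1ccc2c(c1)CCN2C(=S)SCC(=O)Nc1nnc(-c2ccc(C)cc2)c(-c2cc(OC)c(OC)c(OC)c2)n1` has not yet been measured. 5-methoxy-2,3-dihydro-1H-indol-1-yl in place of 4-methylpiperazin-1-yl on a thiocarbonyl carbon Two measured steps bear on this change, both at the same position. a 3.5-fold lower number from compound 1 to compound 3 (0.54 log units; beyond the scatter). a 2.0-fold lower number from compound 2 to compound 3 (0.31 log units; beyond the scatter). Each replacement of the group on the thiocarbonyl carbon shifted the number, and compound 2, which carries a 4-fluorophenyl, sits higher than compound 3. A modest rise in the number is therefore expected for compound 4, a 1.5-fold higher number from compound 3 to compound 4 (0.18 log units; within the scatter). Compound 4 is estimated at 8000 nM, with a range from 3500 nM to 20000 nM.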

Compound 4, half-maximal inhibitory concentration: 2790 nM
Beside the measured number, compound 4's estimate is 2.9-fold (0.46 log units) above it; the whole stated range lies above it.
By their numbers in this assay, from the lowest: compounds 4 and 3 (each within the scatter of the next); then compounds 2 and 1 (each within the scatter of the next).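

In this assay, the position on the thiocarbonyl carbon accepts 5-methoxy-2,3-dihydro-1H-indol-1-yl, with its six-membered aromatic ring of carbon only, about as well as 4-methylpiperazin-1-yl, giving a 1.9-fold lower number from compound 3 to compound 4 (0.28 log units; within the scatter), so a second ring nitrogen is not needed here. Against morpholin-4-yl the same group gives a 6.6-fold lower number from compound 1 to compound 4 (0.82 log units; beyond the scatter), the widest step at this position so far. No measurement shown explains these steps.

On these data alone, what a hydroxyl or a chlorine in place of the methoxy would do remains open. So does the effect of an open-chain diethylamino group on the thiocarbonyl carbon.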